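A few compounds are considered here, and "the series" means these few. Any claim that something is new, unique, unknown or untested is made for them only; others in the source may bear on it.

Of the compounds shown here, two have so far been measured in an assay on isolated protein (Cavia porcellus) with Sigma non-opioid intracellular receptor 1 (Homo sapiens) as the target, read by radioligand binding; a lower number here means a stronger inhibitor, a higher number a weaker inhibitor. Compound 1 `CN(CCCCCCOc1ccc2oc(-c3ccccc3)cc(=O)c2c1)Cc1ccccc1` gives 75 nM, and compound 2 `O=c1cc(-c2cccs2)oc2ccc(OCCCCCCN3CCC(O)CC3)cc12` gives 232 nM; of these two numbers, that of compound 2 is the higher, and the gap to compound 1 lies beyond the usual scatter. Compound 3 `O=c1cc(-c2ccncc2)oc2ccc(OCCCCCCN3CCC(O)CC3)cc12` differs from compound 2 only by pyridin-4-yl in place of thiophen-2-yl on an aromatic carbon. Among the compounds with values here, no measured pair shows this change on its own, so its effect must be judged from the change itself. Compound 3 is expected to move toward a higher number by a modest step, a 2.4-fold higher number from compound 2 to compound 3 (0.37 log units; beyond the scatter). Compound 3 is therefore estimated at 550 nM, within a range from 170 nM to 1800 nM.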

Compound 3, half-maximal inhibitory concentration: 308 nM
Estimate against measurement, compound 3: 1.8-fold (0.25 log units) above, and the stated range covers the measured number.
By their numbers in this assay, from the lowest: compound 1; then compounds 2 and 3 (each within the scatter of the next).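

In this assay, pyridin-4-yl in place of thiophen-2-yl on the aromatic carbon next to the ring oxygen gives a 1.3-fold higher number from compound 2 to compound 3 (0.12 log units; within the scatter) and so leaves the two compounds indistinguishable. Within the data shown here, this is the first single change read at this position, and here a five-membered and a six-membered aromatic ring are not told apart. Nothing available explains why the two rings read alike. The compounds shown leave open whether furan-2-yl or pyridin-3-yl at this position would also fall within the scatter of compound 2. They also leave open what a shorter chain would do with the ring at this position held fixed.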